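The source may report more compounds than this note shows. Statements on the series, on what has been measured and on what is new or still open speak of the compounds shown alone.

Measured compounds:
Compound 1, `C[C@H]1[C@H](NCc2ccc(C(C)(C)C)s2)C[C@H]2C[C@@H]1C2(C)C` — in an ADME assay on MDCK cells (Canis lupus familiaris) for cytotoxicity, read by microscopy, with a stated time of 48 h (on this read-out lower numbers stand for higher toxicity in this test and higher numbers for lower toxicity in this test), compound 1 gives 780 nM
Compound 2, `CSc1ccc(CN[C@@H]2C[C@H]3C[C@@H]([C@H]2C)C3(C)C)s1` — in this assay compound 2 gives 25000 nM
Compound 3, `Cc1ccc(CN[C@@H]2C[C@H]3C[C@@H]([C@H]2C)C3(C)C)s1` — in this assay compound 3 gives 780 nM

Compound 3 is level with compound 1 and these two sit together at the lowest numbers of the three; compound 2 stands far from them, as a 32-fold lower number from compound 2 to compound 3 (1.51 log units; beyond the scatter) shows. The known steps concern only substituents on the thiophene: a 32-fold higher number from compound 1 to compound 2 (1.51 log units; beyond the scatter) and no change at the digits printed from compound 1 to compound 3 (within the scatter). Compound 4, `C[C@H]1[C@H](NCc2cncnc2)C[C@H]2C[C@@H]1C2(C)C`, differs from compound 3 by pyrimidin-5-yl in place of 5-methylthiophen-2-yl on a saturated chain carbon bound to an amine nitrogen. Among the compounds with values here, no measured step covers a swap of the whole aromatic ring, so neither step bears directly on it; the data leave the direction open. The expected outcome is an estimated step of a 3.2-fold higher number from compound 3 to compound 4 (0.51 log units; beyond the scatter). For compound 4 the estimated value in this assay is 2500 nM, with a range from 500 nM to 25000 nM.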

Compound 4, minimum cytotoxic concentration: > 100000 nM
Compound 4 ended at the assay's limit; the forecaster's own chance of this, stated with the estimate: 10%; middle value at least 40-fold (1.60 log units) away from the limit.
By their numbers in this assay, from the lowest: compounds 1 and 3 (each within the scatter of the next); then compound 2. At a limit, above all of these: compound 4.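

Putting pyrimidin-5-yl in place of 5-methylthiophen-2-yl gives an at least 120-fold higher number from compound 3 to compound 4 (2.10 log units; beyond the scatter), so in this assay the change of the aromatic ring itself, and not only of a substituent on the thiophene, can shift the read-out towards lower toxicity in this test. The step is a bound and not an exact size, since compound 4 stands at a limit of the assay: the limit of > 100000 nM in this assay, at which 1 of the 4 values shown sits.

The compounds shown do not separate the change of ring size from the change in hetero atoms. A phenyl or a pyridin-3-yl group at this place would speak to that question.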